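A few compounds are considered here, and "the series" means these few. Any claim that something is new, unique, unknown or untested is made for them only; others in the source may bear on it.

Compound 1 `NS(=O)(=O)N1CCC(C(=O)/C(=N/O)Nc2ccc(F)c(Br)c2)CC1`: 63 nM
Compound 2 `NS(=O)(=O)NC[C@H]1CC[C@H](C(=O)/C(=N/O)Nc2ccc(F)c(Br)c2)CC1`: 198 nM
Compound 3 `O=C(/C(=N/O)Nc1ccc(F)c(Br)c1)C1CCN(S(=O)(=O)NCc2ccccc2)CC1`: 24 nM

In an assay for inhibition of Indoleamine 2,3-dioxygenase 1 (Homo sapiens), with a stated time of 1 h (on this read-out lower numbers stand for stronger inhibition and higher numbers for weaker inhibition), compound 1 stands second highest of the three numbers. Compound 3 lies closest to it, with a 2.6-fold lower number from compound 1 to compound 3 (0.42 log units; beyond the scatter); compound 2, which carries its sulfamide on a chain from the ring rather than on the ring nitrogen, shows the highest number of the three.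

Compound 4 `O=C(/C(=N/O)Nc1ccc(F)c(Br)c1)C1CCN(C(=O)c2ccccc2)CC1` differs from compound 1 in one place: benzoyl in place of sulfamoyl on an amine nitrogen in a ring. Among the compounds with values here, no measured step removes the sulfamoyl group, so the only step that bears on this change is the one from compound 1 to compound 3, where a benzyl on the sulfonamide nitrogen gave a modest gain; it shows that a phenyl ring near this nitrogen has been tolerated once, but it says nothing about losing the sulfamoyl itself. Given that gap, a modest rise in the number is expected, a 1.9-fold higher number from compound 1 to compound 4 (0.28 log units; within the scatter). Compound 4 is therefore estimated at 120 nM, with a range from 35 nM to 450 nM.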

Compound 4, half-maximal inhibitory concentration: 106 nM
Estimate against measurement, compound 4: 1.1-fold (0.05 log units) above; measured number inside the range.
By their numbers in this assay, from the lowest: compound 3; then compounds 1, 4 and 2 (each within the scatter of the next, the first and the last beyond it).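

In this assay, the change from sulfamoyl to benzoyl on the amine nitrogen in the ring (a 1.7-fold higher number from compound 1 to compound 4 (0.23 log units; within the scatter)) shows that this group can be exchanged without a step beyond the scatter. This holds even though benzoyl brings more heavy atoms, an aromatic ring of carbon only and no hydrogen-bond donor. Within the data shown here, the earlier step varied only a substituent on the sulfonamide nitrogen and kept the sulfamoyl in place, so this is the first reading of its removal, and no measurement at hand accounts for the result.

Still open, as far as these compounds go, is how this nitrogen responds to other groups, such as a simple acetyl, a phenylsulfonyl or a directly attached benzyl. Also open, from the compounds shown here alone, is whether a benzoyl carrying a fluorine or a methoxy group on its ring would read differently.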